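The compounds below may be only part of what the source reports. "The series", "measured", "known", "first", "only" and "open" are said of these compounds alone.

Compound 3 `Cn1c(C(=O)Nc2ccccc2)cc2cc(OCCCC3CCN(Cc4ccccc4)CC3)ccc21` carries an anilino group on the carbonyl carbon of the shared core. In an assay on isolated protein for inhibition of Amine oxidase [flavin-containing] B (Homo sapiens), read by fluorescence, with stated times of 30 min and 1 h (on this read-out lower numbers stand for stronger inhibition and higher numbers for weaker inhibition), compound 3 gives > 100000 nM, which is a limit of the assay and not a number. Its closest measured relative, compound 2 `CCOC(=O)c1cc2cc(OCCCC3CCN(Cc4ccccc4)CC3)ccc2n1C`, gives in this assay > 100000 nM, likewise a limit. Compound 1 `COc1ccc2c(c1)cc(CNCc1ccccc1)n2C`, a smaller member of the set, gives > 100000 nM; 100000 nM (2 entries) in this assay. Within the data shown here, the only step measured between neighbours, a step that the two limits leave unreadable from compound 2 to compound 3, therefore has no readable size. Compound 4 `C#CCNC(=O)c1cc2cc(OCCCC3CCN(Cc4ccccc4)CC3)ccc2n1C` differs from compound 3 in one place: propargyl in place of phenyl on an amide-type nitrogen. Among the measured compounds shown here, no measured step involves this change, and the whole set offers no number to anchor it, as the limit of > 100000 nM in this assay, at which 2 of the 3 values shown sit, and the several entries of compound 1 in this assay, > 100000 nM; 100000 nM (2 entries) show. Compound 3 stands only at the limit, so compound 4 is expected to give about 100000 nM, within 20000 nM to 300000 nM. The expected step is accordingly a number no higher from compound 3 to compound 4 (the limit leaves the size open), nothing beyond the scatter.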

Compound 4, half-maximal inhibitory concentration: > 100000 nM
Compound 4 was reported as a limit; the forecaster's own chance of this, stated with the estimate: 70%; the middle value sits exactly at the limit.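

Compound 4 stands at a limit of the assay and not at a number, like compound 2 and compound 3, so no step among these three compounds can be read. The compounds shown leave open whether propargyl in place of phenyl on an amide-type nitrogen changes inhibition at all: the limit of > 100000 nM in this assay, at which 3 of the 4 values shown sit.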